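A few compounds are considered here, and "the series" means these few. Any claim that something is new, unique, unknown or untested is made for them only; others in the source may bear on it.

Of the compounds shown here, three sharing one core have been measured in a functional assay on MGC-803 cells (Homo sapiens) for cytotoxicity, read by MTT assay, with a stated time of 38 h; a lower number here means a stronger inhibitor, a higher number a weaker inhibitor. Compound 1 `COc1cc(OC)c2c(=O)c(OCC(=O)N/N=C/c3ccc(C)cc3)c(-c3cc(OC)c(OC)c(OC)c3)oc2c1` gives 3510 nM, compound 2 `COc1cc(OC)c2c(=O)c(OCCCCN3CCN(C)CC3)c(-c3cc(OC)c(OC)c(OC)c3)oc2c1` gives 12200 nM, and compound 3 `COc1cc(OC)c2c(=O)c(OCC(=O)N/N=C/c3ccco3)c(-c3cc(OC)c(OC)c(OC)c3)oc2c1` gives 6050 nM. Compound 3 therefore lies within the scatter of both other compounds. The next case is compound 4 `CCN(CC)CCCOc1c(-c2cc(OC)c(OC)c(OC)c2)oc2cc(OC)cc(OC)c2c1=O`, which differs from compound 3 by a group of 7 heavy atoms (6 carbon, 1 nitrogen; no ring) in place of a group of 10 heavy atoms (6 carbon, 2 nitrogen, 2 oxygen; one five-membered aromatic ring with 1 hetero atom), on a saturated chain carbon bound to an oxygen on an aromatic ring. The entering group is 2-(diethylamino)ethyl, and it has no ring. Compound 2 is the closest measured comparison, since it too has a chain ending in an amine nitrogen at this place. The data show a 2.0-fold lower number from compound 2 to compound 3 (0.30 log units; within the scatter), which stays within the scatter, while a 3.5-fold higher number from compound 1 to compound 2 (0.54 log units; beyond the scatter) goes beyond it and points the same way. By contrast, a 1.7-fold higher number from compound 1 to compound 3 (0.24 log units; within the scatter) changes only the ring at the chain end and says less about this swap. In this assay a small step toward a higher number is expected, a 1.5-fold higher number from compound 3 to compound 4 (0.17 log units; within the scatter), and it may not clear the scatter. For compound 4 the estimated value is 9000 nM, with an expected range from 3000 nM to 25000 nM.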

Compound 4, half-maximal inhibitory concentration: 40200 nM
For compound 4 the middle estimate is 4.5-fold (0.65 log units) below the measured one; measured number above the stated range.
By their numbers in this assay, from the lowest: compounds 1, 3 and 2 (each within the scatter of the next, the first and the last beyond it); then compound 4.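

For the compounds shown here, at this place, on a saturated chain carbon bound to an oxygen on an aromatic ring, a chain ending in an amine nitrogen does not by itself settle the outcome: diethylamino in place of (4-methylpiperazin-1-yl)methyl gives a 3.3-fold higher number from compound 2 to compound 4 (0.52 log units; beyond the scatter), so the two amine-ended chains are clearly separated. 2-(diethylamino)ethyl is the only group here without a ring, and it leaves compound 4 the weakest of the four, with a 6.6-fold higher number from compound 3 to compound 4 (0.82 log units; beyond the scatter) and an 11-fold higher number from compound 1 to compound 4 (1.06 log units; beyond the scatter). Nothing at hand gives a reason for these steps.

Going by these compounds, the step between the two amine-ended chains removes the ring and changes what sits on the nitrogen at once, so the share of each stays open. A piperidine or a morpholine at the end of the same chain would bear on that question.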